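The source may hold more compounds than are shown below. What is called first, only, known or untested is meant among the compounds shown, and "the series" means these compounds.

Of the compounds shown here, three sharing one core have been measured in a functional assay on MCF7 cells (Homo sapiens) for cytotoxicity, read by MTT assay, with a stated time of 96 h; on this read-out higher numbers stand for weaker inhibition and lower numbers for stronger inhibition. Compound 1 (`COc1cc(C(=O)c2cn(-c3cccc(N)c3)cc2-c2ccc(N)cc2)cc(OC)c1OC`) gives 14 nM, compound 2 (`COc1cc(C(=O)c2cn(-c3ccc(F)cc3)cc2-c2ccccc2F)cc(OC)c1OC`) gives 39 nM, and compound 3 (`COc1cc(C(=O)c2cn(-c3ccc(F)cc3)cc2-c2ccccc2[N+](=O)[O-])cc(OC)c1OC`) gives 38 nM. Compound 3 thus stands level with compound 2 within the scatter, while the number for compound 1 is lower beyond the scatter.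

Compound 4 (`COc1cc(C(=O)c2cn(-c3ccc(F)cc3)cc2-c2ccc(N)cc2)cc(OC)c1OC`) differs from compound 3 in one place: 4-aminophenyl in place of 2-nitrophenyl on an aromatic carbon. In short, 4-aminophenyl stands in place of 2-nitrophenyl on an aromatic carbon. Going by the values given here, the one measured step at this place is a 1.0-fold lower number from compound 2 to compound 3 (0.01 log units; within the scatter). It swaps nitro for fluoro and stays within the scatter, so it says little about a change to 4-aminophenyl. Compound 1 also carries 4-aminophenyl and gives 14 nM, although it differs from compound 4 elsewhere as well. On that evidence, a modest move toward a lower number is expected in this assay. The estimated change is a 1.9-fold lower number from compound 3 to compound 4 (0.28 log units; within the scatter), and it need not pass beyond the scatter. Compound 4 is estimated at 20 nM, with an expected range of 7 nM to 60 nM.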

Compound 4, half-maximal inhibitory concentration: 12 nM
Estimate against measurement, compound 4: 1.7-fold (0.22 log units) above, and the stated range covers the measured number.
By their numbers in this assay, from the lowest: compounds 4 and 1 (each within the scatter of the next); then compounds 3 and 2 (each within the scatter of the next).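

In this assay this aromatic carbon, two ring bonds from the ring nitrogen, proves sensitive to the group it carries: 4-aminophenyl gives a 3.2-fold lower number from compound 3 to compound 4 (0.50 log units; beyond the scatter) in place of 2-nitrophenyl and a 3.3-fold lower number from compound 2 to compound 4 (0.51 log units; beyond the scatter) in place of 2-fluorophenyl. Both steps pass beyond the scatter, whereas the earlier exchange of fluoro for nitro, a 1.0-fold lower number from compound 2 to compound 3 (0.01 log units; within the scatter), did not. With 4-aminophenyl in place on both compounds, 4-fluorophenyl on the ring nitrogen instead of 3-aminophenyl gives a 1.2-fold lower number from compound 1 to compound 4 (0.07 log units; within the scatter), so that change stays within the scatter; nothing measured here offers an explanation for these steps.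

Going by these compounds, it remains open whether the lower numbers follow from the amine itself or from where it sits on the phenyl ring. A 2-aminophenyl, 3-aminophenyl, 4-hydroxyphenyl or unsubstituted phenyl group at this carbon would help to separate those two readings.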